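Branching the Ester Chain in a Thiourea Series

A few compounds are considered here, and "the series" means these few. Any claim that something is new, unique, unknown or untested is made for them only; others in the source may bear on it.

Measured so far:
compound 1, `COC(=O)c1c(NC(=S)Nc2cccc3ccccc23)sc2c1CCCC2`, gives 7330 nM
compound 2, `CCCOC(=O)c1c(NC(=S)Nc2cccc3ccccc23)sc2c1CCCC2`, gives 1050 nM

Both compounds were tested in an assay on HEK-Blue hTLR2 cells for agonist activity at Toll-like receptor 2 (Homo sapiens), with a stated time of 24 h; a higher number here means that more compound is needed for the effect, a lower number that less compound is needed. For the measured compounds named here, compound 2 stands lowest of the two numbers; its only neighbour is compound 1, and the step of a 7.0-fold lower number from compound 1 to compound 2 (0.84 log units; beyond the scatter) is the sole measured change in this set. That step lengthened the chain on the ester oxygen and brought the number down clearly.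

Compound 3, `CC(C)OC(=O)c1c(NC(=S)Nc2cccc3ccccc23)sc2c1CCCC2`, has not been measured. It differs from compound 2 by isopropyl in place of propyl on an oxygen next to a carbonyl group: the same three carbons are kept, only arranged with a branch instead of a straight chain. Going by the values given here, no measured step speaks directly to this kind of rearrangement; the one step known, from compound 1 to compound 2, concerns chain length, not branching. The expectation is therefore cautious: compound 3 is estimated to sit close to compound 2, with the step of a 1.4-fold higher number from compound 2 to compound 3 (0.15 log units; within the scatter) expected to stay within or near the scatter. In this assay compound 3 is estimated at 1500 nM, within a range of 500 nM to 5000 nM.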

Compound 3, half-maximal effective concentration: 140 nM
The estimate for compound 3 lay 11-fold (1.03 log units) above the measured number, outside the stated range (below it).
By their numbers in this assay, from the lowest: compound 3; then compound 2; then compound 1.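

At this position, on an oxygen next to a carbonyl group, the arrangement of the carbons matters and not only their number. Propyl and isopropyl have the same three carbons, yet the change from the straight chain to the branched one gives a 7.5-fold lower number from compound 2 to compound 3 (0.88 log units; beyond the scatter) in this assay, a step that the chain-length comparison could not have revealed. Measured against the methyl ester, isopropyl gives a 52-fold lower number from compound 1 to compound 3 (1.72 log units; beyond the scatter), so among these three compounds the branched chain has the lowest number, and no information is available on why the branch has this effect.

The compounds shown leave open whether the number keeps falling with more branching, as in tert-butyl, with a small ring such as cyclopropyl, or with a longer chain such as butyl. From the compounds shown here alone, it is also open whether isopropyl in place of propyl would bring a similar drop if another part of the shared core were changed, since this comparison rests on a single pair of compounds.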